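Trifluoromethyl in place of bromo: expected maximal response

A few compounds are considered here, and "the series" means these few. Any claim that something is new, unique, unknown or untested is made for them only; others in the source may bear on it.

Three measured compounds share one core. Compound 1 `O=C(O)CCc1ccc(NCc2ccccc2)cc1` carries an aminomethyl link; in a functional assay on 1321-N1 cells for agonist activity at Free fatty acid receptor 1 (Homo sapiens), read by calcium flux (on this read-out higher numbers stand for larger maximal responses and lower numbers for smaller maximal responses), compound 1 gives 89%. Compound 2 `O=C(O)CCc1ccc(OCc2ccccc2Br)cc1` gives 99% in this assay. Compound 3 `O=C(O)CCc1ccc(OCc2cccc(Br)c2)cc1` gives 99% in this assay. Compound 3 stands level with compound 2 at the digits shown, and the value of compound 1 lies within the scatter of both, so these three numbers show no change that can be read as real. Among the compounds with values here, no single-point step between measured compounds is available in this set.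

Compound 4 `O=C(O)CCc1ccc(OCc2cccc(C(F)(F)F)c2)cc1` is not yet measured. It differs from compound 3 by trifluoromethyl in place of bromo on an aromatic carbon. With all three measured values close together, no basis exists for expecting the exchange to move the maximal response beyond the scatter, in either direction. The step expected in this assay is a number 4 percentage points lower from compound 3 to compound 4 (within the scatter), none beyond the scatter. Compound 4 is therefore estimated at 95%, with a range from 75% to 108%.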

Compound 4, largest response reached (reported as efficacy), in percent of the reference or control that the assay uses: 103%
Compound 4: the middle estimate sits 8 percentage points below what was measured; the measured number falls inside the stated range.
By their numbers in this assay, from the lowest: compounds 1, 2, 3 and 4 (each within the scatter of the next, the first and the last beyond it).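

In this assay, within the data shown here, the only single-place exchange in this set gives a number 4 percentage points higher from compound 3 to compound 4 (within the scatter) for trifluoromethyl in place of bromo on an aromatic carbon, meta to a large group. Among these compounds, this place on the ring therefore takes trifluoromethyl, with its 4 heavy atoms, where bromo had 1, and the maximal response stays within the scatter; the earlier compounds offered no single-place step to show this. No measured evidence on the cause accompanies this step.

The compounds shown report only the largest response reached, so any effect of the exchange on the concentration needed for that response stays open. Also open, on these data alone, is whether a nitrile, a methoxy group or a longer chain such as ethyl at this same place would keep the response within the scatter.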